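Tetrazole for Sulfone at the Phenyl Terminus

The source may report more compounds than this note shows. Statements on the series, on what has been measured and on what is new or still open speak of the compounds shown alone.

Measured so far: compound 3 `CC(C)(C)OC(=O)N1CC=C(c2nc(COc3ccc(S(C)(=O)=O)cc3)cs2)CC1`, 678 nM; compound 1 `CC(C)(C)OC(=O)N1CC=C(c2nc(COc3ccc(C4CCCCC4)cc3)cs2)CC1`, "not determined" (no result reported); compound 2 `CCCC(=O)c1ccc(OCc2csc(C3=CCN(C(=O)OC(C)(C)C)CC3)n2)cc1`, "not determined" (no result reported).

Within the data shown here, in a functional assay on isolated protein for agonist activity at Glucose-dependent insulinotropic receptor (Homo sapiens), read by HTRF and cAMP accumulation (a higher number here means that more compound is needed for the effect, a lower number that less compound is needed), compound 3 gives 678 nM, the only number in this set, since compound 1 gives "not determined" (no result reported) and compound 2 gives "not determined" (no result reported). Compound 4 `CC(C)(C)OC(=O)N1CC=C(c2nc(COc3ccc(-n4cnnn4)cc3)cs2)CC1` differs from compound 3 in one place: 1H-tetrazol-1-yl in place of methylsulfonyl on an aromatic carbon. Among the measured compounds shown here, with no second number to compare against, no step between measured compounds can be drawn from these data. The author expects the change in this assay to stay close to the scatter or to cost a little potency, the step from compound 3 to compound 4 being estimated at a 1.6-fold higher number from compound 3 to compound 4 (0.21 log units; within the scatter). Compound 4 is therefore estimated at 1100 nM, within a range of 300 nM to 4000 nM.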

Compound 4, half-maximal effective concentration: 113 nM
Estimate against measurement, compound 4: 9.7-fold (0.99 log units) above; measured number below the stated range.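

In this assay, among these compounds, 1H-tetrazol-1-yl in place of methylsulfonyl gives a 6.0-fold lower number from compound 3 to compound 4 (0.78 log units; beyond the scatter) and provides the first step that can be read in this set. It shows that the group on this aromatic carbon, para to a large group, bears on the concentration needed, and that a five-membered aromatic ring with 4 hetero atoms is accepted there. Nothing measured here explains the step.

On these data alone, whether the gain is specific to tetrazole remains open, as a triazole or a carboxylic acid at this place would show. The tert-butyl carbamate, shared by all the compounds shown, also remains untested against any other group.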